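The source may hold more compounds than are shown below. What is called first, only, known or untested is meant among the compounds shown, and "the series" means these compounds.

Compound 1 `O=C(NCc1ccccc1)c1cn(-c2ccccc2)nc1-c1cccnc1` carries a benzylamino group on a carbonyl carbon of its core. In a functional assay on HeLa cells (Homo sapiens) for cytotoxicity, read by MTT assay, with a stated time of 48 h (a lower number here means a stronger inhibitor, a higher number a weaker inhibitor), compound 1 gives only a limit, > 100000 nM, and not a number; this is the limit of > 100000 nM in this assay, at which 1 of the 2 values shown sits. Compound 2 `O=C(c1cn(-c2ccccc2)nc1-c1cccnc1)N1CCC(Cc2ccccc2)CC1`, which bears a different group on that same carbonyl carbon, gives 25300 nM in this assay. Compound 3 `COc1ccc(OC(=O)c2cn(-c3ccccc3)nc2-c2cccnc2)cc1` has not yet been measured. It differs from compound 1 in one place: 4-methoxyphenoxy in place of benzylamino on a carbonyl carbon. Within the data shown here, no step between two measured compounds covers a change of this kind, so there is little to lean on, and a compound sitting at a limit gives no firm starting number. The step from compound 1 to compound 3 is expected to be an at least 1.1-fold lower number from compound 1 to compound 3 (0.04 log units; that floor lies within the scatter), that is, nothing clearly beyond the scatter, with a real chance that only a limit is reported again. The estimate for compound 3 in this assay is 90000 nM, with a range from 25000 nM to 300000 nM.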

Compound 3, half-maximal inhibitory concentration: > 100000 nM
Compound 3: a limit, no number (the forecaster's own chance of this, stated with the estimate: 55%); at least 1.1-fold (0.04 log units) between middle value and limit.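

Compound 1 and compound 3 each give only a limit and not a number in this assay, so no step can be read between them: the limit of > 100000 nM in this assay, at which 2 of the 3 values shown sit.

Left open is whether 4-methoxyphenoxy and benzylamino on a carbonyl carbon differ at all in this assay, and by how much.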